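The compounds below may be only part of what the source reports. "The series", "measured", "known", "first", "only" and "open" are said of these compounds alone.

Measured compounds:
Compound 1 `CCCn1c(=O)c2nc(-c3cnn(Cc4cccc(C)c4)c3)[nH]c2n(CCC)c1=O` gives 48 nM in an assay on CHO cells for displacement of a labelled ligand from adenosine receptor A1 (Homo sapiens); on this read-out higher numbers stand for weaker inhibition and lower numbers for stronger inhibition.
Compound 2 `CCCCn1c(=O)c2nc(-c3cnn(Cc4ccccc4)c3)[nH]c2n(CCCC)c1=O` gives 1400 nM in this assay.

Compound 1 holds the lower of the two numbers measured in this assay, and its gap to compound 2 is beyond the scatter. Compound 2 differs from compound 1 in more than one place, so its value says nothing on its own about any single change.

Compound 3 `CCCn1c(=O)c2nc(-c3cnn(Cc4cc(Cl)ccc4Cl)c3)[nH]c2n(CCC)c1=O` is not yet measured. Relative to compound 1 the change is 2,5-dichlorophenyl in place of 3-methylphenyl on a saturated chain carbon bound to an aromatic nitrogen. Going by the values given here, no pair of measured compounds differing only in this way is available, so there is no measured step to draw on. The expectation for compound 3 in this assay is a step of a 1.3-fold higher number from compound 1 to compound 3 (0.10 log units; within the scatter), small and without a clear direction, likely within the scatter. Compound 3 is therefore estimated at 60 nM, with a range from 15 nM to 250 nM.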

Compound 3, inhibition constant: 190 nM
Beside the measured number, compound 3's estimate is 3.2-fold (0.50 log units) below it, within the range that was stated.
By their numbers in this assay, from the lowest: compound 1; then compound 3; then compound 2.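

In this assay, going by these compounds alone, 2,5-dichlorophenyl in place of 3-methylphenyl on a saturated chain carbon bound to an aromatic nitrogen gives the first single-change reading for this position (a 4.0-fold higher number from compound 1 to compound 3 (0.60 log units; beyond the scatter)). This position is therefore not indifferent to the substitution on its phenyl ring, and the step is modest but beyond the scatter, with 3-methylphenyl holding the lower number of this pair. Nothing on hand bears on the origin of this step.

No compound shown separates the removal of the methyl from the arrival of either chlorine, so the contribution of each remains open. Also open, from the compounds shown here alone, is how this position responds to a 3-chlorophenyl group, which would set a single chlorine where the methyl stands, or to a phenyl ring carrying an amine or a carboxylic acid.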